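Swapping naphthalen-1-yl for 4-chlorophenoxy, second time around

The source may hold more compounds than are shown below. What is called first, only, known or untested is meant among the compounds shown, and "the series" means these compounds.

Measured so far:
compound 1 `Clc1ccc(Oc2ccc3c(NCCCNCc4ccco4)ccnc3c2)cc1` gives 14500 nM
compound 2 `c1coc(CNCCCNc2ccnc3cc(-c4cccc5ccccc45)ccc23)c1` gives 32000 nM
compound 3 `COc1cccc(CNCCCNc2ccnc3cc(-c4cccc5ccccc45)ccc23)c1O` gives 32000 nM

In a physicochemical assay for solubility, with a stated time of 18 h, at pH 7.4 (on this read-out lower numbers stand for lower solubility and higher numbers for higher solubility), compound 2 and compound 3 stand level; the two cores differ by 2-hydroxy-3-methoxyphenyl in place of furan-2-yl on a saturated chain carbon bound to an amine nitrogen, which left the number unchanged (no change at the digits printed from compound 2 to compound 3 (within the scatter)). The change of interest is 4-chlorophenoxy in place of naphthalen-1-yl on an aromatic carbon, which gave a 2.2-fold lower number from compound 2 to compound 1 (0.34 log units; beyond the scatter). Compound 4 `COc1cccc(CNCCCNc2ccnc3cc(Oc4ccc(Cl)cc4)ccc23)c1O` carries the same change on the core of compound 3: 4-chlorophenoxy in place of naphthalen-1-yl on an aromatic carbon. The place description is identical word for word, so this is the same change, not merely the same kind. Because a 2.2-fold lower number from compound 2 to compound 1 (0.34 log units; beyond the scatter) was modest but beyond the scatter, a step of similar size is expected, a 2.1-fold lower number from compound 3 to compound 4 (0.33 log units; beyond the scatter). Compound 4 is therefore estimated at 15000 nM, between 7000 nM and 32000 nM.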

Compound 4, solubility: 14500 nM
Compound 4: the middle estimate sits 1.0-fold (0.01 log units) above what was measured; low and high end bracket the measured number.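

In this assay, 4-chlorophenoxy in place of naphthalen-1-yl gave a 2.2-fold lower number from compound 3 to compound 4 (0.34 log units; beyond the scatter) and so repeated a 2.2-fold lower number from compound 2 to compound 1 (0.34 log units; beyond the scatter) on a second core. The other difference, 2-hydroxy-3-methoxyphenyl in place of furan-2-yl, gave no change at the digits printed from compound 1 to compound 4 (within the scatter) and so left the number where it was with 4-chlorophenoxy present, as it did with naphthalen-1-yl present. This shows that the change carried over between these two cores, but two cores make no rule for the whole series, and no measurement here explains the step.

Still open, as far as these compounds go, is how the number would move with a carboxylic acid or an amine such as morpholine in place of 4-chlorophenoxy. Also open, from the compounds shown here alone, is whether the same step would appear on a core with a longer chain.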